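Trading a dimethylamino group for a charged, longer chain

The source may report more compounds than this note shows. Statements on the series, on what has been measured and on what is new or still open speak of the compounds shown alone.

Two compounds share one core and differ only in the chain that hangs from an oxygen on an aromatic ring. Compound 1 `O=C(O)COc1c(-c2ccc(O)c(O)c2)oc2ccccc2c1=O` carries a carboxy group there, and in a functional assay for inhibition, with Rattus norvegicus as the target, using microsomes (on this read-out lower numbers stand for stronger inhibition and higher numbers for weaker inhibition), compound 1 gives 6500 nM. Compound 2 `CN(C)CCCOc1c(-c2ccc(O)c(O)c2)oc2ccccc2c1=O` carries a dimethylamino group instead, and in this assay compound 2 gives 1000 nM. That is the lower of the two numbers, with a 6.5-fold lower number from compound 1 to compound 2 (0.81 log units; beyond the scatter).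

Compound 3 `C[N+](C)(C)CCCCCCOc1c(-c2ccc(O)c(O)c2)oc2ccccc2c1=O` is the next step. a group of 7 heavy atoms (6 carbon, 1 nitrogen; no ring) in place of a group of 3 heavy atoms (2 carbon, 1 nitrogen; no ring), on a saturated chain carbon, three bonds along the chain from an oxygen on an aromatic ring

For the measured compounds named here, only the step from compound 1 to compound 2 touches this part of the molecule, and it was modest. It shows that the end of this chain matters, but it says nothing about a longer chain or about a group with a net charge in place of the dimethylamino group. With a single step to lean on, the expectation for compound 3 is a small move, most likely toward a somewhat higher number, given as a 1.8-fold higher number from compound 2 to compound 3 (0.26 log units; within the scatter). In this assay compound 3 is expected to give 1800 nM, within a range from 500 nM to 7000 nM.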

Compound 3, half-maximal inhibitory concentration: 1400 nM
Compound 3: middle estimate off by 1.3-fold (0.11 log units), on the high side; low and high end bracket the measured number.
By their numbers in this assay, from the lowest: compounds 2 and 3 (each within the scatter of the next); then compound 1.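

In this assay, replacing the dimethylamino group with a group of 7 heavy atoms and net charge +1 gives a 1.4-fold higher number from compound 2 to compound 3 (0.15 log units; within the scatter), so this read-out does not tell the two compounds apart. This end of the chain therefore tolerates a clear change in what it carries: a group with no net charge and 1 hydrogen-bond acceptor gives way to a larger one with net charge +1 and 0 hydrogen-bond acceptors, with no shift beyond the scatter. The comparison with the carboxy compound also holds up, with a 4.6-fold lower number from compound 1 to compound 3 (0.67 log units; beyond the scatter), so both nitrogen-bearing chain ends stand apart from the carboxy end of compound 1.

As far as these compounds go, compound 3 alters the size of the group and its charge in a single step, so the contribution of each remains open; a dimethylamino group on a longer chain, or a trimethylammonium group on the shorter chain, would pull the two apart. The data shown also offer no measurement that accounts for these numbers.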